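The source may hold more compounds than are shown below. What is called first, only, known or untested is meant among the compounds shown, and "the series" means these compounds.

Compound 1 `COc1ccc(Cl)cc1C(=O)NCCC1CCN(S(=O)(=O)NC(=O)NC2CCCCC2)CC1`: 25%
Compound 2 `CCCNC(=O)NS(=O)(=O)N1CCC(CCNC(=O)c2cc(Cl)ccc2OC)CC1`: 11%
Compound 3 `COc1ccc(Cl)cc1C(=O)NCCC1CCN(S(=O)(=O)NC(=O)NC[C@H]2C[C@@H]3CC[C@@H]2O3)CC1`: 27%

In a functional assay on the whole organism (blood) with Rattus norvegicus as the target, with stated times of 24 h and 1 h, at a dose of 5 mg/kg by the intraperitoneal route (a higher number here means a stronger effect of the compound at the dose given, a lower number a weaker effect), compound 2 gives 11%, the lowest of the three numbers. Compound 1 gives 25%, and the step of a number 14 percentage points lower from compound 1 to compound 2 (beyond the scatter) lies beyond the scatter. Compound 3 gives 27%, and the step of a number 16 percentage points higher from compound 2 to compound 3 (beyond the scatter) also lies beyond the scatter, while the step of a number 2 percentage points higher from compound 1 to compound 3 (within the scatter) stays within it. Both steps that reach beyond the scatter change the group on the amide-type nitrogen at the urea end of the shared core.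

Compound 4 `CCCNC(=O)NS(=O)(=O)N1CCC(CCNC(=O)c2cc(C(F)(F)F)nn2C)CC1` differs from compound 2 elsewhere: 1-methyl-3-(trifluoromethyl)-1H-pyrazol-5-yl in place of 5-chloro-2-methoxyphenyl on a carbonyl carbon. Within the data shown here, none of the measured steps touches the group on this carbonyl carbon, so no measured step bears directly on the change, and its direction is unknown from these three compounds. With nothing to point either way, the expected step of a number 1 percentage points lower from compound 2 to compound 4 (within the scatter) is one within the scatter. Compound 4 is therefore estimated at 10%, with a range from 0% to 25%.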

Compound 4, a percentage reported as activity, at one dose (the size of the read-out at that dose, not a potency): 11%
The estimate for compound 4 lay 1 percentage points below the measured number, and the stated range covers the measured number.
By their numbers in this assay, from the lowest: compounds 2 and 4 (each within the scatter of the next); then compounds 1 and 3 (each within the scatter of the next).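

Among these compounds, this is the first look at the group on the carbonyl carbon, since the earlier steps all changed the other end of the shared core. In this assay, putting 1-methyl-3-(trifluoromethyl)-1H-pyrazol-5-yl in place of 5-chloro-2-methoxyphenyl gives no change at the digits printed from compound 2 to compound 4 (within the scatter) so a five-membered aromatic ring can stand in for a six-membered aromatic ring of carbon only without moving the read-out. This holds only with propyl at the urea end, where the number was already the low one of the series.

On these data alone, whether the same exchange would leave the number unchanged with the cyclohexyl of compound 1 remains open, as does the outcome for other groups here, such as a phenyl ring carrying a carboxylic acid or an amine. Nothing available accounts for the unchanged number.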